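Amine substituent change in a sigma-1 binding series

This account rests on a few compounds, and the source may have more. Where it says the series, first, only, none or still open, it means among the compounds named here.

Measured compounds:
compound 1 `COc1cccc(/C(C)=C/CN(C)Cc2ccccc2)c1` gives 10 nM
compound 2 `C/C(=C\CN1CCCCC1)c1ccc(-c2ccccc2)cc1` gives 0.86 nM
compound 3 `C/C(=C\CN(C)Cc1ccccc1)c1ccccc1` gives 92 nM

All three were measured in an assay on cell membranes for displacement of a labelled ligand from Sigma non-opioid intracellular receptor 1 (Cavia porcellus), read by scintillation counting, with a stated time of 150 min; on this read-out lower numbers stand for stronger inhibition and higher numbers for weaker inhibition. Compound 1 stands second highest of the three numbers: compound 3 is its nearest neighbour, and compound 2, which carries a different amine and a different aromatic substituent, is the furthest. For the measured compounds named here, the one single-point step in the set, a 9.2-fold higher number from compound 1 to compound 3 (0.96 log units; beyond the scatter), concerns the methoxy on the aromatic ring and leaves the amine untouched.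

Compound 4 `COc1cccc(/C(C)=C/CN(C)C)c1` has not yet been measured. It differs from compound 1 by hydrogen in place of phenyl on a saturated chain carbon bound to an amine nitrogen; cut one bond further out, the change reads benzyl to methyl. Going by the values given here, no measured step bears directly on this change: the step from compound 1 to compound 3 alters a different place, and compound 2 differs from compound 1 in more than one place, so its value can only be noted, not broken down. The benzyl removed here is a substantial part of compound 1, and the expectation is therefore a higher number, with wide uncertainty. Compound 4 is estimated to come out around 150 nM, expected to lie between 30 nM and 800 nM, which would mean an expected step of a 15-fold higher number from compound 1 to compound 4 (1.18 log units; beyond the scatter).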

Compound 4, inhibition constant: > 1000 nM
Compound 4 gave a limit, no number; the forecaster's own chance of this, stated with the estimate: 5%; middle value at least 6.6-fold (0.82 log units) from the limit.
By their numbers in this assay, from the lowest: compound 2; then compound 1; then compound 3. At a limit, above all of these: compound 4.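

In this assay compound 4 gives > 1000 nM, which is a limit and not a number. Hydrogen in place of phenyl on the saturated chain carbon bound to an amine nitrogen gives an at least 100-fold higher number from compound 1 to compound 4 (2.00 log units; beyond the scatter), a larger change than the only earlier single-place step, a 9.2-fold higher number from compound 1 to compound 3 (0.96 log units; beyond the scatter), so the amine substituent, untouched in that earlier step, now stands out as the place in the series where the read-out moves furthest. The step has a lower bound but no measured size, because its end point is a limit: the limit of > 1000 nM in this assay, at which 1 of the 4 values shown sits.

The compounds shown do not tell whether the phenyl ring itself matters or whether any larger group on the amine would serve, and a cyclohexylmethyl or ethyl group in place of the benzyl would separate these two readings. As far as these compounds go, whether the benzyl and methoxy contributions add up also stays open, as does the place of the piperidine amine of compound 2, which differs from compound 1 in more than one place.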